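Compound 4 Against Compound 1: A Larger Group on the Chain

The compounds below may be only part of what the source reports. "The series", "measured", "known", "first", "only" and "open" are said of these compounds alone.

The shared core carries a diamino head, and three compounds have been tested in an ADME assay on Vero cells (Chlorocebus sabaeus) for cytotoxicity, read by MTT assay, with a stated time of 24 h; a lower number here means that less compound is tolerated, a higher number that more compound is tolerated. Compound 1 `CCN(Cc1ccc(OC(F)(F)F)cc1)c1ccc2nc(N)nc(N)c2c1` reaches only a limit of this assay and gives > 200000 nM. Compound 2 `Nc1nc(N)c2cc(NCc3ccc4c(c3)OCCO4)ccc2n1` likewise stops at a limit and gives > 200000 nM. Compound 3 `COc1ccc(CNc2ccc3nc(NC(C)=O)nc(NC(C)=O)c3c2)cc1`, with acetylated amines, gives a number, 156000 nM. So compound 1 stands at the limit of > 200000 nM in this assay, at which 2 of the 3 values shown sit, and nothing separates it from compound 2 on the values shown, while compound 3 lies beneath that limit.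

Compound 4 `COc1ccc(CN(Cc2ccc(OC(F)(F)F)cc2)c2ccc3nc(N)nc(N)c3c2)cc1` differs from compound 1 in one place: 4-methoxyphenyl in place of methyl on a saturated chain carbon bound to a nitrogen on an aromatic ring. Among the measured compounds shown here, no step between measured compounds touches this change, so its effect is unknown here. The three values shown all sit near or at the limit, and a step toward lower tolerance no larger than the scatter is expected, with a fair chance that compound 4 again reaches only a limit. For compound 4 an expected value of 180000 nM, between 80000 nM and 400000 nM, is estimated, meaning a step of an at least 1.1-fold lower number from compound 1 to compound 4 (0.04 log units; that floor lies within the scatter).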

Compound 4, half-maximal cytotoxic concentration: > 200000 nM
Compound 4 gave a limit, no number; the forecaster's own chance of this, stated with the estimate: 55%; middle value at least 1.1-fold (0.04 log units) from the limit.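

Among the compounds shown here, compound 1 and compound 4 each reach only a limit of the assay, and no step between them can be read. The compounds shown leave open whether 4-methoxyphenyl in place of methyl changes the outcome in this assay at all, and by how much.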